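The source may hold more compounds than are shown below. What is called first, only, known or untested is meant among the compounds shown, and "the series" means these compounds.

In a functional assay on Ehrlich cells (Mus musculus) for antiproliferative activity, read by trypan blue exclusion, with a stated time of 2 h (on this read-out higher numbers stand for weaker inhibition and lower numbers for stronger inhibition), compound 3 `COc1cc(CC2C(C#N)=C(N)N(c3ccc(S(N)(=O)=O)cc3)C3=C2C(=O)CCC3)ccc1O` gives 25 ug/mL, the lowest of the two numbers shown. Compound 1 `Cc1ccc(C2C(C#N)=C(N)N(c3ccc(S(N)(=O)=O)cc3)C3=C2C(=O)CCC3)cc1` gives 50 ug/mL, and the step of a 2.0-fold lower number from compound 1 to compound 3 (0.30 log units; within the scatter) stays within the scatter. Compound 2 `N#CC1=C(N)N(c2ccc(S(N)(=O)=O)cc2)C2=C(C(=O)CCC2)C1/C=C/c1ccccc1` reaches only a limit of the assay, > 100 ug/mL. The step of an at least 4.0-fold lower number from compound 2 to compound 3 (0.60 log units; beyond the scatter) lies beyond the scatter. Compound 4 `N#CC1=C(N)N(c2ccc(S(N)(=O)=O)cc2)C2=C(C(=O)CCC2)C1c1ccc(Cl)cc1Cl` has not been measured; it differs from compound 3 in that (2,4-dichlorophenyl in place of 4-hydroxy-3-methoxybenzyl on a saturated ring carbon). Like compound 1, compound 4 carries an aromatic ring on that saturated ring carbon, so the step of a 2.0-fold lower number from compound 1 to compound 3 (0.30 log units; within the scatter) bears on it most, and a number near that of compound 1 is expected. Compound 4 is therefore estimated at 45 ug/mL, between 20 ug/mL and 100 ug/mL. The step of a 1.8-fold higher number from compound 3 to compound 4 (0.26 log units; within the scatter) is expected to stay within the scatter.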

Compound 4, half-maximal inhibitory concentration: 25 ug/mL
The estimate for compound 4 lay 1.8-fold (0.26 log units) above the measured number; the measured number falls inside the stated range.
By their numbers in this assay, from the lowest: compounds 3, 4 and 1 (each within the scatter of the next). At a limit, above all of these: compound 2.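

In this assay, the change to 2,4-dichlorophenyl gives no change at the digits printed from compound 3 to compound 4 (within the scatter) and a 2.0-fold lower number from compound 1 to compound 4 (0.30 log units; within the scatter), so the hydrogen-bond donor and acceptors of 4-hydroxy-3-methoxybenzyl can go from this saturated ring carbon without a step beyond the scatter. The same group gives an at least 4.0-fold lower number from compound 2 to compound 4 (0.60 log units; beyond the scatter), so a second group now stands clear of 2-phenylethenyl. Compound 2 remains the only compound set apart, and its value is a limit: the limit of > 100 ug/mL in this assay, at which 1 of the 4 values shown sits.

On these data alone, whether an amine, a carboxylic acid or a longer alkyl chain on this carbon would move the number stays open.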